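The source may hold more compounds than are shown below. What is called first, only, known or untested is meant among the compounds shown, and "the series" means these compounds.

In a functional assay on KM12 cells (Homo sapiens) for cytotoxicity, read by sulforhodamine B assay, with a stated time of 48 h, tested at 0.01 uM (a lower number here means a stronger effect, a higher number a weaker effect of the compound at the concentration tested), compound 1 `COc1ccc(C(=O)/C=C/c2cc(-c3cc(OC)c(OC)c(OC)c3)n[nH]2)cc1OC` gives 97%. Going by the values given here, compound 2 `COc1cc(-c2cc(/C=C/C(=O)c3ccc(F)c(F)c3)[nH]n2)cc(OC)c1OC` gives 96% in this assay, and the single measured step, a number 1 percentage points lower from compound 1 to compound 2 (within the scatter), keeps the two readings within the scatter, so compound 1 stands level with its only neighbour rather than above it. Compound 3 `COc1cc(C(=O)/C=C/c2cc(-c3cc(OC)c(OC)c(OC)c3)n[nH]2)cc(OC)c1OC` differs from compound 1 in one place: methoxy in place of hydrogen on an aromatic carbon. Among the compounds with values here, no measured step bears directly on this change; the only step known, from compound 1 to compound 2, alters the group on the carbonyl carbon and leaves the reading essentially where it was. With both measured compounds near the top of the scale, there is little room to move upward, and nothing in the data points downward. Compound 3 is therefore expected to give 96%, between 88% and 100%, an expected step of a number 1 percentage points lower from compound 1 to compound 3 (within the scatter) that stays within the scatter.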

Compound 3, a percentage reported as activity, at one concentration (the size of the read-out at that concentration, not a potency): 101%
For compound 3 the middle estimate is 5 percentage points below the measured one, outside the stated range (above it).
By their numbers in this assay, from the lowest: compounds 2, 1 and 3 (each within the scatter of the next).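

In this assay, methoxy in place of hydrogen on an aromatic carbon, ortho to a methoxy group and meta to a large group, gives a number 4 percentage points higher from compound 1 to compound 3 (within the scatter). The earlier step replaced the whole group on the carbonyl carbon, whereas this one shows that a single further methoxy can be placed at this position of the six-membered aromatic ring without a shift beyond the scatter. No measurement among these data accounts for the reading.

The compounds shown leave open whether a hydroxyl, an amine or a carboxylic acid on this same aromatic carbon, or a longer chain such as ethoxy, would move the reading beyond the scatter. They also leave open what removing one of the existing methoxy groups from this ring would do at the concentration tested.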